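Triterpenoid esters: methoxy for methyl on the aryl ester

The source may report more compounds than this note shows. Statements on the series, on what has been measured and on what is new or still open speak of the compounds shown alone.

Two measured members of this series both carry the same core and differ in the group on the ring oxygen side chain. Compound 1 `CC1=CC[C@H]2[C@H](CC[C@]2(C)O)C(C)(C)[C@@H]1CC[C@H]1[C@]2(C)CC[C@H](OC(=O)c3ccc(C)cc3)C(C)(C)O[C@H]2CC[C@@]1(C)O` is an ester bearing a 4-methylphenyl carbonyl. In a functional assay on MDA-MB-231 cells (Homo sapiens) for antiproliferative activity, read by MTT assay, with a stated time of 72 h (a lower number here means a stronger inhibitor, a higher number a weaker inhibitor), compound 1 gives 33400 nM. Compound 2 `CC1=CC[C@H]2[C@@H]1CC=C(C)[C@@H](CC[C@H]1[C@]3(C)CC[C@H](OCc4ccccc4)C(C)(C)O[C@H]3CC[C@@]1(C)O)C2(C)C` carries a benzyl ether in that position instead. In this assay compound 2 gives 35700 nM, and the two numbers lie within the usual scatter of each other, so compound 1 stands at the lower of the two values without that being a real separation.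

Compound 3 `COc1ccc(C(=O)O[C@H]2CC[C@]3(C)[C@H](CC[C@@](C)(O)[C@H]3CC[C@@H]3C(C)=CC[C@H]4[C@H](CC[C@]4(C)O)C3(C)C)OC2(C)C)cc1` is the next compound to be measured. It differs from compound 1 only as follows: methoxy in place of methyl on an aromatic carbon. For the measured compounds named here, no measured pair in this set isolates such a change, so there is nothing to anchor the size of the step. Given that the ester and the ether variants sit at the same level, compound 3 is expected to stay close to compound 1, with the step of a 1.1-fold lower number from compound 1 to compound 3 (0.05 log units; within the scatter) judged to lie within the scatter. The estimate for compound 3 in this assay is 30000 nM, with a range from 12000 nM to 75000 nM.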

Compound 3, half-maximal inhibitory concentration: 30600 nM
Compound 3: the middle estimate sits 1.0-fold (0.01 log units) below what was measured; low and high end bracket the measured number.
By their numbers in this assay, from the lowest: compounds 3, 1 and 2 (each within the scatter of the next).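

In this assay, for the compounds shown here, replacing 4-methylphenyl with 4-methoxyphenyl on the ester gives a 1.1-fold lower number from compound 1 to compound 3 (0.04 log units; within the scatter), the first measured step that isolates a single change on this aromatic ring. At this place, on an aromatic carbon para to a large group, methyl and methoxy therefore cannot be told apart, even though methoxy brings a hydrogen-bond acceptor that methyl lacks. No measured evidence on the series bears on this result.

The compounds shown leave open whether any substituent at this ring carbon moves the number beyond the scatter, for example an amine or a carboxylic acid in place of methoxy. Also open, on these data alone, is whether a longer chain, such as ethoxy or butoxy, would do so at the same place.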